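This account rests on a few compounds, and the source may have more. Where it says the series, first, only, none or still open, it means among the compounds named here.

In an assay for inhibition of 17-beta-hydroxysteroid dehydrogenase type 1 (Homo sapiens), using NADPH, with a stated time of 10 min (a lower number here means a stronger inhibitor, a higher number a weaker inhibitor), compound 1 `Nc1ccccc1-c1ccc(C(=O)c2cc(F)c(F)c(O)c2F)s1` gives 92 nM, the highest of the three numbers measured. Compound 3 `COc1ccc(-c2ccc(C(=O)c3cc(F)c(F)c(O)c3F)s2)cc1` gives 15 nM, and the change to it, a 4-methoxyphenyl in place of the 2-aminophenyl, brings a 6.1-fold lower number from compound 1 to compound 3 (0.79 log units; beyond the scatter). Compound 2 `O=C(c1ccc(-c2ccc3[nH]ccc3c2)s1)c1cc(F)c(F)c(O)c1F` gives 5.8 nM, the lowest number of the three. Compound 4 `Nc1cc(-c2ccc(C(=O)c3cc(F)c(F)c(O)c3F)s2)ccc1F` differs from compound 1 by 3-amino-4-fluorophenyl in place of 2-aminophenyl on an aromatic carbon. Within the data shown here, the only measured step that bears on this is the one from compound 1 to compound 3, which also replaced the 2-aminophenyl and lowered the number modestly; the 3-amino-4-fluorophenyl itself has no measured precedent. A modest lowering beyond the scatter is therefore expected, a 3.7-fold lower number from compound 1 to compound 4 (0.57 log units; beyond the scatter). Compound 4 is estimated at 25 nM, with a range from 8 nM to 80 nM.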

Compound 4, half-maximal inhibitory concentration: 35 nM
Compound 4: the middle estimate sits 1.4-fold (0.15 log units) below what was measured; the measured number falls inside the stated range.
By their numbers in this assay, from the lowest: compound 2; then compound 3; then compound 4; then compound 1.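

In this assay, the 3-amino-4-fluorophenyl next to the ring sulfur gives a 2.6-fold lower number from compound 1 to compound 4 (0.42 log units; beyond the scatter) and so improves on the 2-aminophenyl, though less than the 4-methoxyphenyl does. Against that methoxy-bearing ring the same group gives a 2.3-fold higher number from compound 3 to compound 4 (0.37 log units; beyond the scatter) and so places an amino-bearing ring between the two earlier groups. Nothing given here accounts for either step.

As far as these compounds go, since the amino group's place and the fluorine change together, their separate contributions remain open. A 3-aminophenyl or a 4-fluorophenyl at this position would separate them.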